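The source may report more compounds than this note shows. Statements on the series, on what has been measured and on what is new or still open speak of the compounds shown alone.

Working notes on the oleamide series in an assay on microsomes from intestine for inhibition of acyl-CoA:cholesterol acyltransferase (Oryctolagus cuniculus); on this read-out lower numbers stand for stronger inhibition and higher numbers for weaker inhibition. Compound 1 `CCCCCCCC/C=C/CCCCCCCC(=O)Nc1ccccc1C(C)C` gives 600 nM; compound 2 `CCCCCCCC/C=C/CCCCCCCC(=O)Nc1ccc(OC)cc1OC` gives 3000 nM; compound 3 `CCCCCCCC/C=C/CCCCCCCC(=O)Nc1ccc(F)cc1F` gives 32000 nM, the highest number of the three, set apart from compound 2 by an 11-fold higher number from compound 2 to compound 3 (1.03 log units; beyond the scatter) and from compound 1 by a 53-fold higher number from compound 1 to compound 3 (1.73 log units; beyond the scatter). Compound 4 `CCCCCCCC/C=C/CCCCCCCC(=O)Nc1cccc(C)c1[N+](=O)[O-]` is the next in line, with 3-methyl-2-nitrophenyl in place of 2,4-difluorophenyl on an amide-type nitrogen. Both known steps that put 2,4-difluorophenyl onto the amide-type nitrogen raised the number by a large margin, so removing it in favour of 3-methyl-2-nitrophenyl is expected to move the number down, likely by a size resembling the step from compound 2 rather than that from compound 1, since neither aryl group matches the incoming one. Compound 4 is estimated at 3000 nM, range 800 nM to 12000 nM, that is an 11-fold lower number from compound 3 to compound 4 (1.03 log units; beyond the scatter).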

Compound 4, half-maximal inhibitory concentration: 12000 nM
Estimate against measurement, compound 4: 4.0-fold (0.60 log units) below; the range from low to high includes it.
By their numbers in this assay, from the lowest: compound 1; then compound 2; then compound 4; then compound 3.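

In (this assay), 3-methyl-2-nitrophenyl on an amide-type nitrogen gives a lower number than 2,4-difluorophenyl (a 2.7-fold lower number from compound 3 to compound 4 (0.43 log units; beyond the scatter)), yet a higher number than either of the other two aryl groups (a 4.0-fold higher number from compound 2 to compound 4 (0.60 log units; beyond the scatter); a 20-fold higher number from compound 1 to compound 4 (1.30 log units; beyond the scatter)). The series therefore runs in four separate steps, from 2-isopropylphenyl through 2,4-dimethoxyphenyl and 3-methyl-2-nitrophenyl to 2,4-difluorophenyl. Nothing at hand accounts for this order. On these data alone, it remains open whether the methyl or the nitro group sets the new value, and where a phenyl carrying an amine or a carboxylic acid would fall.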